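This account rests on a few compounds, and the source may have more. Where it says the series, first, only, none or still open, it means among the compounds named here.

Compound 2 `COc1cc(O)c(C(=O)/C=C/c2ccccc2OC)c(OC)c1` is reported in a functional assay on Huh-7 cells (Homo sapiens), read by fluorescence and BrdU incorporation, with a stated time of 48 h, tested at 25 uM (on this read-out lower numbers stand for a stronger effect and higher numbers for a weaker effect at the one concentration tested), as "not active" (no number reported), with no number given, so it stands apart from compound 1 `COc1cc(OC)c(C(=O)/C=C/c2ccccc2SC)c(OC)c1`, which gives 0.3%, and from compound 3 `COc1cc(OC)c(C(=O)/C=C/c2ccc(Cl)cc2)c(OC)c1`, which gives 0.8%. Compound 4 `COc1cc(O)c(C(=O)/C=C/c2ccccc2SC)c(OC)c1` carries methylsulfanyl in place of methoxy on an aromatic carbon. Within the data shown here, the only measured step, a number 0.5 percentage points higher from compound 1 to compound 3 (within the scatter), alters a different part of the structure and does not bear on this change. Among the measured compounds shown here, no measured step joins compound 2 to any other compound, and the difference between compound 1 and compound 2 covers two changes at once, so nothing isolates this swap. No direction beyond the scatter can be expected in this assay. Compound 4 is estimated at 80%, within 35% to 105%.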

Compound 4, a percentage reported as activity, at one concentration (the size of the read-out at that concentration, not a potency): 37%
Compound 4: middle estimate off by 43 percentage points, on the high side; measured number inside the range.
By their numbers in this assay, from the lowest: compounds 1 and 3 (each within the scatter of the next); then compound 4.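

In this assay, among these compounds, with the 2-(methylsulfanyl)phenyl kept, hydrogen in place of methyl on the ring oxygen is the first single change to move the number beyond the scatter: a number 36.7 percentage points higher from compound 1 to compound 4 (beyond the scatter), which means a weaker effect. Compound 2, with methoxy in place of methylsulfanyl, has no number, so its step to compound 4 cannot be read, and compound 4 at 37% gives no size for that swap. No measurement at hand accounts for either change.

Going by these compounds, whether hydrogen in place of methyl costs as much with the 4-chlorophenyl stays open. So does the effect of an amine or a longer alkoxy chain on that aromatic carbon.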